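Swapping chloro for a thiazolylmethoxy group in compound 1

The compounds below may be only part of what the source reports. "The series", "measured", "known", "first", "only" and "open" are said of these compounds alone.

Compound 1, with the structure `COC(=O)N[C@H](C(=O)NN(CCC[C@@](O)(Cc1ccccc1)C(=O)N[C@H]1c2ccccc2C[C@H]1O)Cc1ccc(Cl)cc1)C(C)(C)C`, carries a chloro group on its outer benzene ring. In an ADME assay on MT4 cells (Homo sapiens) for cytotoxicity (a higher number here means that more compound is tolerated, a lower number that less compound is tolerated), compound 1 gives only a limit, > 10000 nM, not a measured number. Two relatives replace that chloro group. Compound 2, `COC(=O)N[C@H](C(=O)NN(CCC[C@@](O)(Cc1ccccc1)C(=O)N[C@H]1c2ccccc2C[C@H]1O)Cc1ccc(-c2cncnc2)cc1)C(C)(C)C`, carries pyrimidin-5-yl in its place; in this assay compound 2 likewise gives a limit, > 10000 nM. Compound 3, `COC(=O)N[C@H](C(=O)NN(CCC[C@@](O)(Cc1ccccc1)C(=O)N[C@H]1c2ccccc2C[C@H]1O)Cc1ccc(-c2noc(C)n2)cc1)C(C)(C)C`, carries 5-methyl-1,2,4-oxadiazol-3-yl there; in this assay compound 3 again gives a limit, > 10000 nM. The steps a step that the two limits leave unreadable from compound 1 to compound 2 and a step that the two limits leave unreadable from compound 1 to compound 3 therefore cannot be sized, because the limit of > 10000 nM in this assay, at which 3 of the 3 values shown sit, shows every result resting on the same limit.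

Compound 4, `COC(=O)N[C@H](C(=O)NN(CCC[C@@](O)(Cc1ccccc1)C(=O)N[C@H]1c2ccccc2C[C@H]1O)Cc1ccc(OCc2cnc(Cl)s2)cc1)C(C)(C)C`, makes a related change: (2-chloro-1,3-thiazol-5-yl)methoxy in place of chloro on an aromatic carbon. The measured steps that bear on it, both replacements of chloro by an aromatic ring, gave no readable movement, so in this assay no step beyond the scatter is expected, and compound 4 is expected to sit at 15000 nM, within 8000 nM to 40000 nM, most likely again reported as a limit; the implied step that the limit leaves unreadable from compound 1 to compound 4 is expected to be negligible.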

Compound 4, half-maximal cytotoxic concentration: > 10000 nM
Compound 4: only a limit was reported; the forecaster's own chance of this, stated with the estimate: 85%; the middle value is on the limit's open side.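

In this assay compound 4 gives > 10000 nM as a limit and not a number. Its steps from compound 1, compound 2 and compound 3 therefore cannot be read: the limit of > 10000 nM in this assay, at which 4 of the 4 values shown sit. The compounds shown leave open where each half-maximal cytotoxic concentration actually lies, and whether the four differ at all.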